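Adding a chloro to compound 1

This account rests on a few compounds, and the source may have more. Where it says the series, first, only, none or still open, it means among the compounds named here.

For the measured compounds named here, in a functional assay on CCRF-CEM cells (Homo sapiens) for inhibition (a higher number here means a weaker inhibitor, a lower number a stronger inhibitor), compound 1 `O=C1CCCCC/C1=C\c1ccccc1` gives 110000 nM and sits in the middle of the three numbers so far. Compound 2 `O=C1CCCCC/C1=C\c1cccc(F)c1` gives 224000 nM and compound 3 `O=C1CCCCC/C1=C\c1cccc(Cl)c1` gives 40500 nM in the same read-out.

Compound 4 `O=C1CCCCC/C1=C\c1ccc(Cl)cc1` is not yet measured. It keeps the core of compound 1 and has chloro in place of hydrogen on an aromatic carbon, para to a group of 9 heavy atoms (chloro in place of hydrogen on an aromatic carbon).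

The closest measured step is a 2.7-fold lower number from compound 1 to compound 3 (0.43 log units; beyond the scatter) with the same exchange at another place on that ring. The fluoro step is a 2.0-fold higher number from compound 1 to compound 2 (0.31 log units; beyond the scatter) and runs the other way, while a 5.5-fold lower number from compound 2 to compound 3 (0.74 log units; beyond the scatter) separates the two halogens at that place. Going by the values given here, no measured compound shows what moving the chloro does. Going by a 2.7-fold lower number from compound 1 to compound 3 (0.43 log units; beyond the scatter) alone, a modest step to a lower number is expected in this assay of similar size or smaller. The estimated step is a 2.0-fold lower number from compound 1 to compound 4 (0.30 log units; within the scatter) as a working figure. The expected value of compound 4 is 55000 nM within a range of 22000 nM to 120000 nM as estimated here.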

Compound 4, half-maximal inhibitory concentration: 43500 nM
Compound 4: middle estimate off by 1.3-fold (0.10 log units), on the high side, within the range that was stated.
By their numbers in this assay, from the lowest: compounds 3 and 4 (each within the scatter of the next); then compound 1; then compound 2.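

In this assay, chloro in place of hydrogen on an aromatic carbon, para to a group of 9 heavy atoms, gives a 2.5-fold lower number from compound 1 to compound 4 (0.40 log units; beyond the scatter), so the lower number seen with the chloro of compound 3 is not confined to one place on the ring. Compound 3 at 40500 nM and compound 4 at 43500 nM lie within the scatter of each other, so the two chloro placements cannot be told apart in this read-out. Nothing available bears on the cause of this step.

As far as these compounds go, whether fluoro at this place would raise the number, as it does in compound 2, remains open. Also open, from the compounds shown here alone, is whether a methoxy group or an amine at this place would keep the lower number seen with chloro.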